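Removing a Core Methyl: Expected Cytotoxicity of Compound 4

The source may report more compounds than this note shows. Statements on the series, on what has been measured and on what is new or still open speak of the compounds shown alone.

Measured compounds:
Compound 1 `Cc1ccc(CSc2cc(Cl)c(C)cc2S(=O)(=O)/N=C(\N)n2nc(C)cc2-c2ccccc2)cc1`: 62000 nM
Compound 2 `Cc1cc(-c2ccccc2)n(/C(N)=N/S(=O)(=O)c2cc(C)c(Cl)cc2SCc2cccc(C(F)(F)F)c2)n1`: 98000 nM
Compound 3 `Cc1cc(-c2ccccc2)n(/C(N)=N/S(=O)(=O)c2cc(C)c(Cl)cc2SCc2ccccc2C)n1`: 160000 nM

All three were tested in a functional assay on HeLa cells (Homo sapiens) for cytotoxicity, read by MTT assay, with a stated time of 72 h; on this read-out lower numbers stand for stronger inhibition and higher numbers for weaker inhibition. Compound 1 stands at the lowest of the three numbers, though its nearest neighbour, compound 2, sits within the scatter of it. The step of a 1.6-fold higher number from compound 1 to compound 2 (0.20 log units; within the scatter) and the step of a 1.6-fold higher number from compound 2 to compound 3 (0.21 log units; within the scatter) both stay inside the scatter, while the step of a 2.6-fold higher number from compound 1 to compound 3 (0.41 log units; beyond the scatter) goes beyond it, if only modestly. All three steps vary the aryl group on a saturated chain carbon bound to a sulfur; the shared core is untouched in every one of them.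

Compound 4 `Cc1ccc(CSc2cc(Cl)c(C)cc2S(=O)(=O)/N=C(\N)n2nccc2-c2ccccc2)cc1` has not yet been measured. It differs from compound 1 by hydrogen in place of methyl on an aromatic carbon. Within the data shown here, no measured step bears on this position, so there is no direct guide for the size or direction of the change. The three measured values span a narrow band, and a single small change on the core gives no reason to expect a departure from it. Compound 4 is therefore expected to give 70000 nM in this assay, with a range from 30000 nM to 160000 nM. The step of a 1.1-fold higher number from compound 1 to compound 4 (0.05 log units; within the scatter) is expected to remain within the scatter.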

Compound 4, half-maximal inhibitory concentration: 17000 nM
Compound 4: the middle estimate sits 4.1-fold (0.61 log units) above what was measured; the whole stated range lies above it.
By their numbers in this assay, from the lowest: compound 4; then compounds 1, 2 and 3 (each within the scatter of the next, the first and the last beyond it).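

Among these compounds, replacing the methyl with hydrogen on the aromatic carbon of the five-membered aromatic ring with 2 nitrogen gives a 3.6-fold lower number from compound 1 to compound 4 (0.56 log units; beyond the scatter) in this assay and shows that this position on the shared core bears on the read-out, which the earlier steps, all confined to the aryl group on the saturated chain carbon, could not show. Those earlier steps from compound 1 either stayed within the scatter or led to a higher number, so this is the only step shown from compound 1 that leads to a lower number beyond the scatter, though only modestly. Among the compounds shown here, nothing available accounts for the change, and the single step gives its size and direction but no cause.

The compounds shown leave open how an ethyl chain, a chlorine atom or an amine on this aromatic carbon would compare with hydrogen and methyl. They also leave open whether hydrogen in place of methyl would lower the number in the same way with the 3-(trifluoromethyl)phenyl group of compound 2 or the 2-methylphenyl group of compound 3 in place of the 4-methylphenyl group.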